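This account rests on a few compounds, and the source may have more. Where it says the series, first, only, none or still open, it means among the compounds named here.

Measured compounds in a functional assay on HeLa cells (Homo sapiens) for inhibition, read by sulforhodamine B assay, with a stated time of 48 h; on this read-out higher numbers stand for weaker inhibition of growth and lower numbers for stronger inhibition of growth:
Compound 1 `CC(=O)OC/C(=C\c1ccc(F)cc1)C(=O)c1ccccc1` gives 25000 nM.
Compound 2 `CC(=O)OC/C(=C\c1ccccc1F)C(=O)c1ccccc1` gives 22000 nM.
Compound 3 `C=C(C/C(=C\c1ccc(F)cc1)C(=O)c1ccccc1)C(=O)c1ccccc1` gives 18000 nM.

Compound 2 differs from compound 1 by 2-fluorophenyl in place of 4-fluorophenyl on a double-bonded chain carbon bound to a double-bonded chain carbon, and this change brought a 1.1-fold lower number from compound 1 to compound 2 (0.06 log units; within the scatter). The core of compound 3 differs from the core of compound 1, but that difference is not broken down here; what the two values show is that compound 3 and compound 1 lie within the scatter of each other.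

Compound 4 `C=C(C/C(=C\c1ccccc1F)C(=O)c1ccccc1)C(=O)c1ccccc1` has not been measured. It differs from compound 3 by 2-fluorophenyl in place of 4-fluorophenyl on a double-bonded chain carbon bound to a double-bonded chain carbon, the same change as from compound 1 to compound 2, at the same place. On that earlier step, compound 3 to compound 4 is expected to give a 1.1-fold lower number from compound 3 to compound 4 (0.05 log units; within the scatter), because a 1.1-fold lower number from compound 1 to compound 2 (0.06 log units; within the scatter) was within the scatter. Compound 4 is therefore estimated at 16000 nM in this assay, expected between 8000 nM and 32000 nM.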

Compound 4, concentration for 50% growth inhibition: 20000 nM
Beside the measured number, compound 4's estimate is 1.3-fold (0.10 log units) below it; measured number inside the range.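

In this assay, 2-fluorophenyl in place of 4-fluorophenyl gave a 1.1-fold higher number from compound 3 to compound 4 (0.05 log units; within the scatter). Set beside the earlier step, the change carried from one core to the other with no difference that can be read: the same change on two cores in this assay, a 1.1-fold lower number (0.06 log units; within the scatter) from compound 1 to compound 2 and a 1.1-fold higher number (0.05 log units; within the scatter) from compound 3 to compound 4, 1.3-fold (0.10 log units) apart, within the scatter of two such steps

Within the data shown here, this shows only that the change left the number within the scatter on both cores; the opposite directions of the two small steps carry no meaning, and two cores do not establish how the change behaves on any other core. Going by these compounds, what a chlorine, a methoxy group or an amine in place of the fluorine would do on either core remains open. So does whether any such group would move the number beyond the scatter.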